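Swapping Nitro for Bromo on the Aryl Thiazole

This account rests on a few compounds, and the source may have more. Where it says the series, first, only, none or still open, it means among the compounds named here.

Compound 1 `Cc1ccc(-c2csc(N3N=C(c4ccc(C)s4)CC3c3ccc(F)cc3)n2)cc1`: in a functional assay on A549 cells (Homo sapiens) for antiproliferative activity, read by XTT assay, with a stated time of 24 h (on this read-out higher numbers stand for weaker inhibition and lower numbers for stronger inhibition), compound 1 gives > 500 ug/mL, a limit of the assay.
Compound 2 `Cc1ccc(C2=NN(c3nc(-c4ccccc4)cs3)C(c3ccc(F)cc3)C2)s1`: in this assay compound 2 gives > 500 ug/mL, a limit of the assay.
Compound 3 `Cc1ccc(C2=NN(c3nc(-c4ccc([N+](=O)[O-])cc4)cs3)C(c3ccc(F)cc3)C2)s1`: in this assay compound 3 gives 16.7 ug/mL.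

Compound 3 thus holds the only number of the three, the other two values being limits, as shown by the limit of > 500 ug/mL in this assay, at which 2 of the 3 values shown sit. Its standing rests on an at least 29-fold lower number from compound 1 to compound 3 (1.47 log units; beyond the scatter) and on an at least 29-fold lower number from compound 2 to compound 3 (1.47 log units; beyond the scatter). Compound 4 `Cc1ccc(C2=NN(c3nc(-c4ccc(Br)cc4)cs3)C(c3ccc(F)cc3)C2)s1` differs from compound 3 by bromo in place of nitro on an aromatic carbon. Within the data shown here, no measured step touches bromo itself, but both steps toward nitro were large and in the same direction, so leaving nitro is expected to cost much of that gain: in this assay the expected step is a 9.0-fold higher number from compound 3 to compound 4 (0.95 log units; beyond the scatter). For compound 4 the estimate in this assay is 150 ug/mL, expected between 25 ug/mL and 500 ug/mL.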

Compound 4, half-maximal inhibitory concentration: > 500 ug/mL
Compound 4: only a limit was reported (the forecaster's own chance of this, stated with the estimate: 40%); at least 3.3-fold (0.52 log units) between middle value and limit.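

In this assay, bromo does not keep what nitro gave on this six-membered aromatic ring: the change brings an at least 29-fold higher number from compound 3 to compound 4 (1.47 log units; beyond the scatter). With methyl in compound 1, hydrogen in compound 2 and bromo in compound 4 all at one limit of the assay, nitro is the only group shown here that gives a number: the limit of > 500 ug/mL in this assay, at which 3 of the 4 values shown sit. The steps from compound 1 and from compound 2 to compound 4 cannot be read, since both ends of each are limits.

The compounds shown leave open whether a nitrile, an amine or a carboxylic acid at this place would give a number. They also leave open how much of the activity of compound 3 depends on nitro itself.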